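Compound 2 loses a methyl

This account rests on a few compounds, and the source may have more. Where it says the series, first, only, none or still open, it means among the compounds named here.

In a functional assay on KB cells (Homo sapiens) for antiproliferative activity, read by MTT assay (on this read-out lower numbers stand for stronger inhibition and higher numbers for weaker inhibition), compound 2 `COc1cc(OC)c(-c2nc(N3CCN(C)CC3)nc3ccccc23)c(OC)c1` gives 50 ug/mL. It stands level with compound 1 `COc1ccc(-c2nc(N3CCNCC3)nc3ccccc23)c(OC)c1` at 50 ug/mL and with compound 3 `c1ccc2c(c1)ccn2-c1nc(N2CCCCC2)nc2ccccc12` at 50 ug/mL. Compound 4 `COc1cc(OC)c(-c2nc(N3CCNCC3)nc3ccccc23)c(OC)c1` differs from compound 2 in one place: hydrogen in place of methyl on an amine nitrogen in a ring. This puts hydrogen in place of methyl on an amine nitrogen in a ring, turning 4-methylpiperazin-1-yl into piperazin-1-yl. Among the compounds with values here, no measured pair shows this change on its own. Compound 1 carries the same piperazin-1-yl group and gives 50 ug/mL, so no step beyond the usual scatter is expected in this assay. The expected step, a 1.3-fold lower number from compound 2 to compound 4 (0.10 log units; within the scatter), is an estimate. Compound 4 is estimated at 40 ug/mL, with an expected range from 12 ug/mL to 60 ug/mL.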

Compound 4, half-maximal inhibitory concentration: 50 ug/mL
Beside the measured number, compound 4's estimate is 1.3-fold (0.10 log units) below it; measured number inside the range.
By their numbers in this assay, from the lowest: compounds 1, 2, 3 and 4 (each within the scatter of the next).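

In this assay, within the data shown here, the first direct reading of this position shows no change at the digits printed from compound 2 to compound 4 (within the scatter) when hydrogen replaces methyl on the amine nitrogen in the ring, and the piperazin-1-yl group also tolerates methoxy in place of hydrogen on an aromatic carbon, with no change at the digits printed from compound 1 to compound 4 (within the scatter). Neither single change moves the read-out in these compounds. Nothing available gives a reason for this flat result. The compounds shown leave open whether a longer chain or an acetyl group on that nitrogen would shift the number from the level all four share.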